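From Dodecyl to tert-Butyl: An Untested Step

The source may report more compounds than this note shows. Statements on the series, on what has been measured and on what is new or still open speak of the compounds shown alone.

Compound 1 `COC(=O)[C@H](C)NC(=O)c1ccc(Oc2nc3ccccc3nc2NC(C)(C)C)cc1` gives 42200 nM
Compound 2 `CC[C@@H](C)[C@H](NC(=O)c1ccc(Oc2nc3ccccc3nc2NC(C)(C)C)cc1)C(=O)OC` gives 38700 nM
Compound 3 `CCCCCCCCCCCCNc1nc2ccccc2nc1Oc1ccc(C(=O)N[C@H](C(=O)O)[C@H](C)CC)cc1` gives 21500 nM

In a functional assay on K562 cells (Homo sapiens) for antiproliferative activity, read by MTT assay, with a stated time of 48 h (a lower number here means a stronger inhibitor, a higher number a weaker inhibitor), compound 3 lies within the scatter of both compound 1 and compound 2. Compound 4 `CC[C@@H](C)[C@H](NC(=O)c1ccc(Oc2nc3ccccc3nc2NC(C)(C)C)cc1)C(=O)O` differs from compound 3 by tert-butyl in place of dodecyl on a nitrogen on an aromatic ring with tert-butyl in place of dodecyl on a nitrogen on an aromatic ring. Among the compounds with values here, the only measured step, a 1.1-fold lower number from compound 1 to compound 2 (0.04 log units; within the scatter) lies elsewhere in the structure, so no measured step tests this change directly. Compound 1 and compound 2 carry tert-butyl on that nitrogen, but they also differ from compound 4 elsewhere. No shift beyond the scatter is therefore expected in this assay and the estimated step is a 1.4-fold higher number from compound 3 to compound 4 (0.14 log units; within the scatter) in size. For compound 4 the estimate is 30000 nM with an expected range from 12000 nM to 75000 nM as a cautious guess.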

Compound 4, half-maximal inhibitory concentration: 18300 nM
Compound 4: the middle estimate sits 1.6-fold (0.21 log units) above what was measured; low and high end bracket the measured number.
By their numbers in this assay, from the lowest: compounds 4, 3, 2 and 1 (each within the scatter of the next, the first and the last beyond it).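

In this assay the change on the nitrogen on an aromatic ring, tert-butyl in place of dodecyl, gives only a 1.2-fold lower number from compound 3 to compound 4 (0.07 log units; within the scatter) and so makes no clear difference at this position. Hydrogen in place of methyl on the oxygen next to a carbonyl group gives a 2.1-fold lower number from compound 2 to compound 4 (0.33 log units; beyond the scatter) as a modest first shift beyond the scatter. Changing the group on the amide-type nitrogen to 1-carboxy-2-methylbutyl gives a 2.3-fold lower number from compound 1 to compound 4 (0.36 log units; beyond the scatter) and is also modest. From the compounds shown here alone, the effect of a hexyl chain on that aromatic-ring nitrogen, or of an amine in place of the carboxylic acid, remains open. Nothing available explains these shifts.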